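The source may report more compounds than this note shows. Statements on the series, on what has been measured and on what is new or still open speak of the compounds shown alone.

Working notes on the series. For the measured compounds named here, in a functional assay on the whole organism with Rattus norvegicus as the target, at a dose of 40 mg/kg by the intraperitoneal route (on this read-out higher numbers stand for more inhibition at the one dose given (going by the name of the read-out) and lower numbers for less inhibition), compound 1 `Cc1nc2c(OCc3ccccc3)nccn2c1N` gives 79%, and compound 2 `Cc1nc2c(OCc3ccccc3)cccn2c1NC=O` gives 49%; compound 2 stands lowest of the two numbers in this assay, with compound 1 the only comparison, a higher number beyond the scatter. Compound 3 `CCCN(CCC)c1c(C)nc2c(OCc3ccccc3)cccn12` is not yet measured. It differs from compound 2 by dipropylamino in place of formylamino on an aromatic carbon. Going by the values given here, no measured pair shows this change, so the step from compound 2 to compound 3 is expected to be small, with no direction beyond the scatter, as a number 4 percentage points lower from compound 2 to compound 3 (within the scatter). Compound 3 is thus estimated at 45% in this assay, within 15% to 75%.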

Compound 3, a percentage reported as inhibition, in the whole organism at one dose (the size of the read-out at that dose, not a potency): 60%
Beside the measured number, compound 3's estimate is 15 percentage points below it; low and high end bracket the measured number.
By their numbers in this assay, from the lowest: compound 2; then compound 3; then compound 1.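

Dipropylamino in place of formylamino on this aromatic carbon of the five-membered ring gives, in this assay, a number 11 percentage points higher from compound 2 to compound 3 (beyond the scatter). For the compounds shown here, this is the first single change measured at this position, and the formylamino group, with its hydrogen-bond donor, is not needed for the inhibition seen at this dose. No measured property of these compounds accounts for the step.

Still open, on these data alone, is whether the step follows the two propyl chains or the removal of the formyl group. Dimethylamino or a single propylamino on the same core would separate these.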